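This account rests on a few compounds, and the source may have more. Where it says the series, first, only, none or still open, it means among the compounds named here.

In a functional assay on DU-145 cells (Homo sapiens) for cytotoxicity, read by MTT assay (a higher number here means a weaker inhibitor, a lower number a stronger inhibitor), compound 3 `CC(O)(CS(=O)(=O)c1ccc(F)cc1)c1nc(-c2ccc([N+](=O)[O-])c(C(F)(F)F)c2)no1` gives only a limit, > 100000 nM, and no number. Compound 1 `CC(O)(CSc1ccccc1)c1nc(-c2ccccc2)no1` gives only a limit in this assay as well, > 100000 nM. Compound 2 `CC(O)(CS(=O)(=O)c1ccc(Cl)cc1)c1nc(-c2ccc(Cl)cc2)no1` likewise gives only a limit in this assay, > 100000 nM. Compound 3 therefore has no place on a scale of numbers; it sits, like the others, at the limit of > 100000 nM in this assay, at which 3 of the 3 values shown sit.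

Compound 4 `CC(O)(CSc1ccc(Cl)cc1)c1nc(-c2ccc([N+](=O)[O-])c(C(F)(F)F)c2)no1` has not been measured in this assay. It differs from compound 3 by (4-chlorophenyl)sulfanyl in place of (4-fluorophenyl)sulfonyl on a saturated chain carbon, two bonds along the chain from an aromatic carbon and an oxygen on a saturated carbon. Going by the values given here, no step between two measured compounds is known, so the size of the step can rest only on what the three values show. Compound 1, whose chain also carries a sulfanyl link rather than a sulfonyl, gives only a limit in this assay, > 100000 nM. On that ground no step beyond the scatter is expected, and the expected step is a number no higher from compound 3 to compound 4 (the limit leaves the size open). Compound 4 is expected to give 100000 nM in this assay, within 30000 nM to 300000 nM, most probably again only as a limit.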

Compound 4, half-maximal inhibitory concentration: 1300 nM
Compound 4: middle estimate off by 77-fold (1.89 log units), on the high side; measured number below the stated range.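

In this assay, (4-chlorophenyl)sulfanyl in place of (4-fluorophenyl)sulfonyl on a saturated chain carbon gives an at least 76-fold lower number from compound 3 to compound 4 (1.88 log units; beyond the scatter). This shows that the group at this position can by itself move a compound from a limit to a measured number, with the rest of the structure unchanged. Compound 4 is the only compound shown with a number, and the others remain at a limit: the limit of > 100000 nM in this assay, at which 3 of the 4 values shown sit.

The change alters both the sulfur link and the halogen on the ring, and the compounds shown do not tell which of the two carries the step. As far as these compounds go, it also remains open how a sulfinyl link, an amine or a longer chain at this position would read in this assay.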